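Compound 1 to compound 4: replacing the 4-bromophenyl group

The source may hold more compounds than are shown below. What is called first, only, known or untested is meant among the compounds shown, and "the series" means these compounds.

Compound 1 `C#CCSc1nc(Sc2nccs2)c(C#N)c(-c2ccc(Br)cc2)n1`: 12100 nM
Compound 2 `C#CCSc1nc(Sc2nc[nH]n2)c(C#N)c(-c2cc(OC)c(OC)c(OC)c2)n1`: > 20000 nM (a limit)
Compound 3 `C#CCSc1nc(Sc2nc3ccccc3s2)c(C#N)c(-c2cc(OC)c(OC)c(OC)c2)n1`: > 20000 nM (a limit)

Among the compounds with values here, in a functional assay on PC-9 cells (Homo sapiens) for antiproliferative activity, read by MTT assay (a lower number here means a stronger inhibitor, a higher number a weaker inhibitor), compound 1 is the only compound with a true number, standing at 12100 nM. The other two compounds are known only through (the limit of > 20000 nM in this assay, at which 2 of the 3 values shown sit), so compound 1 has no measured neighbour to be ranked against.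

Compound 4 `C#CCSc1nc(Sc2nccs2)c(C#N)c(-c2ccc[nH]2)n1` carries 1H-pyrrol-2-yl in place of 4-bromophenyl on an aromatic carbon of the core of compound 1, next to the ring nitrogen and ortho to a cyano group (1H-pyrrol-2-yl in place of 4-bromophenyl on an aromatic carbon).

Within the data shown here, the one measured step, a step that the two limits leave unreadable from compound 2 to compound 3, cannot be read and lies on a sulfur, not at this place, so it gives no size for this change. The expectation in this assay therefore rests on compound 1 at 12100 nM, with no direction favoured. A reading at the limit is quite possible for compound 4. The estimated change is a 1.1-fold higher number from compound 1 to compound 4 (0.03 log units; within the scatter), and it is expected to be small. For compound 4 the estimate is 13000 nM, with an expected range of 5000 nM to 25000 nM.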

Compound 4, half-maximal inhibitory concentration: > 20000 nM
Compound 4: a limit, no number (the forecaster's own chance of this, stated with the estimate: 35%); middle value at least 1.5-fold (0.18 log units) from the limit.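

Within the data shown here, at this position, on an aromatic carbon of the core ortho to a cyano group, 1H-pyrrol-2-yl in place of 4-bromophenyl gives the first readable step in this assay: an at least 1.6-fold higher number from compound 1 to compound 4 (0.21 log units; that floor lies within the scatter). The smaller five-membered ring with its hydrogen-bond donor therefore brings no sign of a gain, but the floor of this step does not establish a real loss either. Compound 1 remains the only compound with a true number, and the readable range of the series stays narrow: the limit of > 20000 nM in this assay, at which 3 of the 4 values shown sit.

From the compounds shown here alone, how far compound 4 lies beyond its limit remains open, so the size of this change is unknown. Also open, going by these compounds, is whether a 4-aminophenyl or a 4-carboxyphenyl group at this position would give a lower number than compound 1.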